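Swapping the aryl group on a piperazine ring

The source may report more compounds than this note shows. Statements on the series, on what has been measured and on what is new or still open speak of the compounds shown alone.

Measured so far:
compound 1 `CCCc1nc(-c2ccccc2)c(CNCCCN2CCN(c3cccc(C(F)(F)F)c3)CC2)o1` — 51.6%
compound 2 `Cc1nc(-c2ccccc2)c(CNCCCN2CCN(c3ccc(Cl)cc3)CC2)o1` — 38.1%
compound 3 `CCCc1nc(-c2ccccc2)c(CNCCN2CCN(c3ccccc3C(F)(F)F)CC2)o1` — 54.6%

The three compounds share a common core and were examined in an assay on HEK293 cells for inhibition of Voltage-dependent T-type calcium channel subunit alpha-1G (Homo sapiens), read by fluorescence, tested at 10 uM; on this read-out higher numbers stand for more inhibition at the one concentration tested (going by the name of the read-out) and lower numbers for less inhibition. Compound 1 gives 51.6% and stands second highest of the three numbers. Its nearest neighbour is compound 3, which gives 54.6%, a number within the usual scatter of compound 1, so no order between the two can be claimed. Compound 2, the furthest away, gives 38.1%, which lies beyond the scatter below compound 1; compound 2 differs from compound 1 in more than one place, so its lower value cannot be tied to any single change.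

Compound 4 `CCCc1nc(-c2ccccc2)c(CNCCCN2CCN(c3ccc(C)c(C)c3)CC2)o1` has not yet been measured. It differs from compound 1 in one place: 3,4-dimethylphenyl in place of 3-(trifluoromethyl)phenyl on an amine nitrogen in a ring. Within the data shown here, no directly comparable pair is available for this change, so the expected step of a number 6.6 percentage points lower from compound 1 to compound 4 (within the scatter) is set small, with a slight lean downward but not clearly beyond the scatter. The estimate for compound 4 in this assay is 45%, with a likely range from 25% to 65%.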

Compound 4, a percentage reported as inhibition, at one concentration (the size of the read-out at that concentration, not a potency): 54.6%
Compound 4: middle estimate off by 9.6 percentage points, on the low side, and the stated range covers the measured number.
By their numbers in this assay, from the lowest: compound 2; then compounds 1, 3 and 4 (each within the scatter of the next).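

In this assay, among these compounds, the one pair that differs in a single place gives a number 3 percentage points higher from compound 1 to compound 4 (within the scatter), so this swap on an amine nitrogen in a ring leaves the number inside the usual scatter. For this pair, then, 3-(trifluoromethyl)phenyl, a group of 10 heavy atoms that includes fluorine, can give way to 3,4-dimethylphenyl, a group of 8 heavy atoms that are all carbon, without a difference that this read-out can separate from repeat-to-repeat variation. Nothing measured here bears on why the two groups read alike.

Still open, from the compounds shown here alone, is whether a more different group on that same nitrogen, such as a pyridine ring, a benzyl group or a phenyl ring carrying a carboxylic acid, would move the number beyond the scatter. Also open, going by these compounds, is whether this swap would read the same way with another chain or another substituent on the shared core, and whether a full concentration series would separate two compounds that look alike at the single concentration tested here.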